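The compounds below may be only part of what the source reports. "The series", "measured", "known", "first", "only" and "open" are said of these compounds alone.

Compound 1, with structure `C/C(=N\Cc1ccccc1C)c1c(O)c2ccccc2oc1=O`, was tested in an assay on isolated protein for inhibition of myosin-2 (Bos taurus), read by spectrophotometry, with a stated time of 24 min; on this read-out higher numbers stand for weaker inhibition and lower numbers for stronger inhibition. In this assay compound 1 reaches only the limit of the measurement, reported as >= 100000 nM. Compound 2, with structure `C/C(=N\OCc1ccccc1)c1c(O)c2ccccc2oc1=O`, stands at the same limit, giving >= 100000 nM in this assay. Compound 3, with structure `C/C(=N\Cc1ccccc1)c1c(O)c2ccccc2n(C)c1=O`, likewise gives only the limit of >= 100000 nM in this assay. So compound 1 has no measured number of its own to stand on; every value shown sits at the limit of >= 100000 nM in this assay, at which 3 of the 3 values shown sit, and no step between measured compounds can be drawn from these data.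

Compound 4, with structure `C/C(=N\Cc1ccc(C)cc1)c1c(O)c2ccccc2oc1=O`, is the compound not yet measured. It differs from compound 1 by 4-methylphenyl in place of 2-methylphenyl on a saturated chain carbon bound to a double-bonded nitrogen, with the two structures made of the same atoms joined differently. With every measured compound at the limit, no direction of change beyond the scatter can be supported. Compound 4 is therefore expected to sit near the same limit, with an estimated step from compound 1 to compound 4 of a number no higher from compound 1 to compound 4 (the limit leaves the size open). For compound 4 the estimate in this assay is 100000 nM, within a range from 30000 nM to 200000 nM.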

Compound 4, half-maximal inhibitory concentration: 7900 nM
The estimate for compound 4 lay 13-fold (1.10 log units) above the measured number, and the stated range ends above it.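

Exchanging 2-methylphenyl for 4-methylphenyl on a saturated chain carbon bound to a double-bonded nitrogen gives an at least 12-fold lower number from compound 1 to compound 4 (1.10 log units; beyond the scatter) in this assay, so this position responds to a change even when the atoms stay the same. Compound 4 alone has a measured number rather than a limit: the limit of >= 100000 nM in this assay, at which 3 of the 4 values shown sit. For this pair, the choice between two groups made of the same atoms decides whether a number can be read at all.

The compounds shown leave open how 4-chlorophenyl, 4-methoxyphenyl or a longer chain such as 2-phenylethyl would fare at this position, so one measured number gives no trend across groups. Steps among the compounds that sit at the limit cannot be read.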